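Amide in place of a methoxymethyl on the side chain

The source may report more compounds than this note shows. Statements on the series, on what has been measured and on what is new or still open speak of the compounds shown alone.

The series shares one core, shown in compound 1 `Cn1ncc(Cl)c1-c1cc(C(=O)N[C@@H]2CN[C@H](CC(=O)O)C[C@H]2c2ccc(Cl)c(Cl)c2)oc1Cl`, and varies the group on a saturated chain carbon bound to a saturated ring carbon. In a functional assay on HCT-116 cells (Homo sapiens) for antiproliferative activity, read by sulforhodamine B assay, with a stated time of 72 h (a lower number here means a stronger inhibitor, a higher number a weaker inhibitor), compound 1 gives 4020 nM. Compound 2 `Cn1ncc(Cl)c1-c1cc(C(=O)N[C@@H]2CN[C@H](CCN3CCC(O)CC3)C[C@H]2c2ccc(Cl)c(Cl)c2)oc1Cl` gives 13700 nM, and compound 3 `COCC[C@@H]1C[C@@H](c2ccc(Cl)c(Cl)c2)[C@H](NC(=O)c2cc(-c3c(Cl)cnn3C)c(Cl)o2)CN1` gives 470 nM, the lowest of the three numbers, with compound 1 nearest and compound 2 furthest. The steps of an 8.6-fold lower number from compound 1 to compound 3 (0.93 log units; beyond the scatter) and a 3.4-fold higher number from compound 1 to compound 2 (0.53 log units; beyond the scatter) both go beyond the scatter, and a 29-fold lower number from compound 2 to compound 3 (1.46 log units; beyond the scatter) is the largest of them.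

Compound 4 `Cn1ncc(Cl)c1-c1cc(C(=O)N[C@@H]2CN[C@H](CC(N)=O)C[C@H]2c2ccc(Cl)c(Cl)c2)oc1Cl` differs from compound 3 by carbamoyl in place of methoxymethyl on a saturated chain carbon bound to a saturated ring carbon. Among the measured compounds shown here, no measured step carries a carbamoyl. The closest guide is compound 1, whose carboxy differs from the entering carbamoyl only in the heteroatom, and there an 8.6-fold lower number from compound 1 to compound 3 (0.93 log units; beyond the scatter) shows that moving from carboxy to methoxymethyl lowered the number; the reverse direction is therefore expected here, a step of a 5.3-fold higher number from compound 3 to compound 4 (0.73 log units; beyond the scatter). Compound 4 is estimated at 2500 nM, between 800 nM and 8000 nM.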

Compound 4, half-maximal inhibitory concentration: 650 nM
Beside the measured number, compound 4's estimate is 3.8-fold (0.59 log units) above it; the whole stated range lies above it.
By their numbers in this assay, from the lowest: compounds 3 and 4 (each within the scatter of the next); then compound 1; then compound 2.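

In this assay, carbamoyl in place of methoxymethyl on a saturated chain carbon bound to a saturated ring carbon leaves the reading within the scatter (a 1.4-fold higher number from compound 3 to compound 4 (0.14 log units; within the scatter)), so the hydrogen-bond donor that carbamoyl adds does not separate these two compounds. Amino in place of hydroxy on a carbonyl carbon gives a step beyond the scatter (a 6.2-fold lower number from compound 1 to compound 4 (0.79 log units; beyond the scatter)), and the step from the (4-hydroxypiperidin-1-yl)methyl compound is large (a 21-fold lower number from compound 2 to compound 4 (1.32 log units; beyond the scatter)), which shows that a carbonyl group at this place is compatible with a low number when it carries amino rather than hydroxy. Nothing available here accounts for these steps.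

The compounds shown leave open how a methyl-substituted amide, a simple primary amine or a longer chain ending in carbamoyl would read at this place. They also leave open whether a small alcohol would match compound 3 and compound 4.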